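From an iodo group to a trifluoromethylphenyl group

The source may hold more compounds than are shown below. What is called first, only, known or untested is meant among the compounds shown, and "the series" means these compounds.

Compound 3 `O=C(CCc1cccc2c1B(O)OC2)Nc1cccc(I)c1` is the only one of three amides with a readable number in an ADME assay on WI-38 cells (Homo sapiens) for cytotoxicity, read by MTT assay, with a stated time of 72 h; on this read-out higher numbers stand for weaker inhibition and lower numbers for stronger inhibition: compound 3 gives 71000 nM. Compound 1 `O=C(CCc1cccc2c1B(O)OC2)NC1CCCCC1` reaches only the limit of > 100000 nM in this assay. Compound 2 `Cc1ccc(NC(=O)CCc2cccc3c2B(O)OC3)cc1` likewise sits at the limit of > 100000 nM. The steps of an at least 1.4-fold lower number from compound 1 to compound 3 (0.14 log units; that floor lies within the scatter) and an at least 1.4-fold lower number from compound 2 to compound 3 (0.14 log units; that floor lies within the scatter) are floors that lie within the scatter, and a step that the two limits leave unreadable from compound 1 to compound 2 cannot be read. Compound 4 `O=C(CCc1cccc2c1B(O)OC2)Nc1cccc(-c2cccc(C(F)(F)F)c2)c1` differs from compound 3 by 3-(trifluoromethyl)phenyl in place of iodo on an aromatic carbon. Going by the values given here, no measured step touches this same place, so the known steps bear on it only loosely. The step of no change at the digits printed from compound 3 to compound 4 (within the scatter) is expected to be no larger than the scatter, given (the limit of > 100000 nM in this assay, at which 2 of the 3 values shown sit). Compound 4 is estimated at 71000 nM, between 30000 nM and 150000 nM.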

Compound 4, half-maximal inhibitory concentration: 23000 nM
Beside the measured number, compound 4's estimate is 3.1-fold (0.49 log units) above it, and the stated range ends above it.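

Placing 3-(trifluoromethyl)phenyl on this aromatic carbon gives a 3.1-fold lower number from compound 3 to compound 4 (0.49 log units; beyond the scatter) in this assay. This is the only step shown that reads beyond the scatter, whereas the earlier steps, all at the amide-type nitrogen, were floors within the scatter or unreadable. The change is modest, and the numbers still rest on few compounds: the limit of > 100000 nM in this assay, at which 2 of the 4 values shown sit.

The compounds shown leave open whether an unsubstituted phenyl at this place would give the same step. They also leave open how an amine or a carboxylic acid on the added ring would move the number.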